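The compounds below may be only part of what the source reports. "The series", "measured", "known", "first", "only" and "open" are said of these compounds alone.

For the measured compounds named here, compound 2, `Cc1ccc(N2CC(c3nc(-c4cccc(Cl)c4)no3)CC2=O)cc1C`, is the only member of this small set with a number in an in vitro functional assay on HEK293-A cells for positive allosteric modulation of metabotropic glutamate receptor 5 (Homo sapiens), read by FLIPR and calcium flux; a higher number here means that more compound is needed for the effect, a lower number that less compound is needed: in this assay compound 2 gives 310 nM. Its companion, compound 1, `O=C1CC(c2nc(-c3cccc(Cl)c3)no2)CN1c1ccccc1Cl`, stands at a limit of the assay rather than at a number, giving > 10000 nM in this assay. Going by the values given here, the one measured step that leads to compound 2 is large: an at least 32-fold lower number from compound 1 to compound 2 (1.50 log units; beyond the scatter).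

Compound 3, `Cc1ccccc1N1CC(c2nc(-c3cccc(Cl)c3)no2)CC1=O`, differs from compound 2 in the same position of the shared core: 2-methylphenyl in place of 3,4-dimethylphenyl on an amide-type nitrogen in a ring. Among the compounds with values here, the only step that bears on this change is the one from compound 1 to compound 2, where a 2-chlorophenyl on the same ring nitrogen went with a value at the assay limit (the limit of > 10000 nM in this assay, at which 1 of the 2 values shown sits). Compound 3 carries a 2-methylphenyl, and on that evidence the change is expected to go the opposite way from the measured step, towards a higher number, with a real chance that compound 3 again sits at the limit. The expected step is a 9.7-fold higher number from compound 2 to compound 3 (0.99 log units; beyond the scatter). For compound 3 the estimate in this assay is 3000 nM, within a range from 700 nM to 12000 nM.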

Compound 3, half-maximal effective concentration: > 10000 nM
Compound 3 was reported as a limit; the forecaster's own chance of this, stated with the estimate: 40%; at least 3.3-fold (0.52 log units) between middle value and limit.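

On the amide-type nitrogen in a ring, 2-methylphenyl in place of 3,4-dimethylphenyl gives an at least 32-fold higher number from compound 2 to compound 3 (1.50 log units; beyond the scatter) in this assay, so this position responds strongly even to a change between two aromatic groups of carbon only. The earlier step left open whether the loss of a number went with the chloro group, but compound 3 has a methyl where compound 1 has a chloro and is also reported only as a limit. Of the three groups shown at this position, only 3,4-dimethylphenyl gives a number, while 2-chlorophenyl and 2-methylphenyl do not: the limit of > 10000 nM in this assay, at which 2 of the 3 values shown sit.

The step from compound 1 to compound 3 cannot be read, as both values are limits, so the chloro and methyl groups remain unranked against each other. Also open, going by these compounds, is which part of the 3,4-dimethylphenyl goes with the measurable value, and whether an unsubstituted phenyl, or a methoxy group, an amine or a carboxylic acid on that aromatic ring, would give a number in this assay.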